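Thiourea to urea swap on a weakly active sulfonamide

This account rests on a few compounds, and the source may have more. Where it says the series, first, only, none or still open, it means among the compounds named here.

Compound 1 `O=C(NCCNS(=O)(=O)c1ccc(-c2ccccc2OCc2ccccc2)s1)Nc1cc(Cl)cc(Cl)c1`: > 20000 nM
Compound 2 `O=[N+]([O-])c1ccc(NC(=S)NCCNS(=O)(=O)c2ccc(-c3ccccc3OCc3ccccc3)s2)cc1`: 11300 nM

In a functional assay on RS4-11 cells (Homo sapiens) for inhibition, read by CCK-8 assay, with a stated time of 48 h (on this read-out lower numbers stand for stronger inhibition and higher numbers for weaker inhibition), compound 1 reaches only the assay's limit, > 20000 nM. Going by the values given here, compound 2 gives 11300 nM in this assay, the one number reported here; the step of an at least 1.7-fold lower number from compound 1 to compound 2 (0.24 log units; that floor lies within the scatter) rests on a floor that sits inside the scatter (the limit of > 20000 nM in this assay, at which 1 of the 2 values shown sits). Compound 3 `O=C(NCCNS(=O)(=O)c1ccc(-c2ccccc2OCc2ccccc2)s1)Nc1cccc([N+](=O)[O-])c1` differs from compound 2 by a group of 12 heavy atoms (7 carbon, 2 nitrogen, 3 oxygen; one six-membered aromatic ring of carbon only) in place of a group of 12 heavy atoms (7 carbon, 2 nitrogen, 2 oxygen, 1 sulfur; one six-membered aromatic ring of carbon only), on an amine nitrogen. Among the compounds with values here, the single measured step bears on this change, and it was small, so compound 3 is expected to shift little, a 1.3-fold higher number from compound 2 to compound 3 (0.12 log units; within the scatter). Compound 3 is estimated at 15000 nM (range 5000 nM to 40000 nM), with a fair chance of landing back at the limit.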

Compound 3, half-maximal inhibitory concentration: > 20000 nM
Compound 3 was reported as a limit; the forecaster's own chance of this, stated with the estimate: 40%; middle value at least 1.3-fold (0.12 log units) away from the limit.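

Putting (3-nitrophenyl)carbamoyl on the amine nitrogen in place of the sulfur-containing group gives an at least 1.7-fold higher number from compound 2 to compound 3 (0.24 log units; that floor lies within the scatter), so this assay shows no clear change at this position. Compound 1 and compound 3 are both limits, and the step between them cannot be read. Neither the 3,5-dichlorophenyl nor the 3-nitrophenyl urea therefore yields a true number: the limit of > 20000 nM in this assay, at which 2 of the 3 values shown sit.

From the compounds shown here alone, whether any urea here gives a measurable value stays open. So does the reading of a phenyl ring carrying an amine or a carboxylic acid in place of the nitro group.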